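This account rests on a few compounds, and the source may have more. Where it says the series, first, only, none or still open, it means among the compounds named here.

Working notes on the series. Compound 1 `O=C(CN1CCN(c2ccccn2)CC1)Nc1cncnc1` and compound 2 `Cc1cccc(NC(=O)CN2CCN(c3ncccn3)CC2)c1` share a piperazine-linked acetamide core and were both run in a functional assay on cells for agonist activity at D(4) dopamine receptor (Homo sapiens), read by TR-FRET and cAMP accumulation, with a stated time of 30 min; on this read-out lower numbers stand for smaller maximal responses and higher numbers for larger maximal responses. In this assay compound 1 gives "not active" (no number reported), a result reported without a number. In this assay, going by the values given here, compound 2 gives 64.6%, the only numerical value in the set so far; compound 1 and compound 2 differ at more than one place, so no single structural step can be read from their pair.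

Compound 3 `Cc1cccc(NC(=O)CN2CCN(c3ccccn3)CC2)c1` is the next entry to be measured in this assay. It differs from compound 2 by pyridin-2-yl in place of pyrimidin-2-yl on an amine nitrogen in a ring. Compound 1 also carries pyridin-2-yl on the ring nitrogen and gave "not active" (no number reported), but its other difference from compound 2 prevents a clean comparison, so the expectation rests mainly on compound 2 at 64.6%. For compound 3 the maximal response in this assay is estimated at 50%. The plausible range for compound 3 is estimated to run from 20% to 78%. The step this estimate implies, a number 14.6 percentage points lower from compound 2 to compound 3 (beyond the scatter), is expected to be a decrease of modest size, somewhat beyond the usual scatter but not a loss of activity.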

Compound 3, largest response reached (Emax), in percent of the reference or control that the assay uses: 64.2%
The estimate for compound 3 lay 14.2 percentage points below the measured number; the range from low to high includes it.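

Going by these compounds alone, the change to pyridin-2-yl from pyrimidin-2-yl on an amine nitrogen in a ring gives a number 0.4 percentage points lower from compound 2 to compound 3 (within the scatter) in this assay, the only single-place step so far, and it shows that on this core the maximal response does not separate the two rings, although the hetero atom count falls from 2 to 1. Pyridin-2-yl at this place is also compatible with a numerical response: compound 1 carries the same group and gives "not active" (no number reported), whereas compound 3 gives 64.2%, so that group alone does not go with the missing number for compound 1. No measurement at hand bears on why the step is this small.

Still open, from the compounds shown here alone, is how far this tolerance extends on the ring nitrogen, for instance to a plain phenyl ring, a saturated ring such as cyclohexyl, or a ring bearing a carboxylic acid or an amine. Also open, going by these compounds, is whether the same exchange stays this small with a different group on the amide nitrogen, since the step is read only with the group shared by compound 2 and compound 3.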